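A few compounds are considered here, and "the series" means these few. Any claim that something is new, unique, unknown or untested is made for them only; others in the source may bear on it.

Measured so far in a functional assay on OVCAR-3 cells (Homo sapiens) for antiproliferative activity, read by MTT assay, with a stated time of 24 h (on this read-out lower numbers stand for stronger inhibition and higher numbers for weaker inhibition), are two compounds:
compound 1 `O=C(NNc1ccccc1Cl)c1ccc(NS(=O)(=O)c2cnc(O)nc2O)cc1` gives 7230 nM
compound 2 `O=C(NNc1ccccc1F)c1ccccc1NS(=O)(=O)c1cnc(O)nc1O` gives 9570 nM

For the measured compounds named here, compound 1 and compound 2 lie within the scatter of each other, so compound 1 stands level with the only other compound measured. Compound 3 `Cc1ccccc1C(=O)NNC(=O)c1ccc(NS(=O)(=O)c2cnc(O)nc2O)cc1` has not yet been measured. It carries (2-methylphenyl)carbonyl in place of 2-chlorophenyl on an amine nitrogen, and (2-methylphenyl)carbonyl in place of 2-chlorophenyl on an amine nitrogen gives the count of that change. Going by the values given here, no measured pair shows a change of this kind, so the data give no direct guide to its size. In this assay only a modest move towards a higher number is expected, quite possibly none beyond the scatter. The estimate means a 1.2-fold higher number from compound 1 to compound 3 (0.10 log units; within the scatter) as the expected step. For compound 3 the estimated value is 9000 nM with an expected range from 3000 nM to 27000 nM on this read-out.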

Compound 3, half-maximal inhibitory concentration: > 20000 nM
Compound 3 was reported as a limit; the forecaster's own chance of this, stated with the estimate: 8%; at least 2.2-fold (0.34 log units) between middle value and limit.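

In this assay, compound 3 is reported only as a limit, > 20000 nM. On an amine nitrogen whose other neighbour is an amide-type nitrogen, (2-methylphenyl)carbonyl in place of 2-chlorophenyl gives an at least 2.7-fold higher number from compound 1 to compound 3 (0.44 log units; beyond the scatter), so this place does respond to change, which the two earlier compounds, lying within the scatter of each other and differing in more than one place, could not show. The step is a bound and not a size: the limit of > 20000 nM in this assay, at which 1 of the 3 values shown sits.

Two things change together here, the added carbonyl and the methyl in place of the chlorine, and the compounds shown do not tell which of them carries the step. They also leave open how 2-methylphenyl set directly on that amine nitrogen, or an acetyl group there, would read.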